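Aromatic five-membered ring replacing oxolane in the series

The compounds below may be only part of what the source reports. "The series", "measured", "known", "first", "only" and "open" are said of these compounds alone.

The series shares the core of compound 1 `CCc1ccc(-c2nc(N)c3cc(Cc4ccccc4)sc3n2)o1` and varies the group on an aromatic carbon of the six-membered ring. In a functional assay on CHO-K1 cells for antagonist activity at adenosine receptor A1 (Homo sapiens), read by a beta-galactosidase reporter and cAMP accumulation, with stated times of 15 min and 6 h (a higher number here means a weaker inhibitor, a lower number a stronger inhibitor), compound 1 gives 223 nM, compound 2 `CC(C)c1ccc(-c2nc(N)c3cc(Cc4ccccc4)sc3n2)o1` gives 283 nM, and compound 3 `Nc1nc(C2CCCO2)nc2sc(Cc3ccccc3)cc12` gives 2950 nM, the highest number of the three. The steps of a 13-fold higher number from compound 1 to compound 3 (1.12 log units; beyond the scatter) and a 10-fold higher number from compound 2 to compound 3 (1.02 log units; beyond the scatter) are both beyond the scatter, whereas a 1.3-fold higher number from compound 1 to compound 2 (0.10 log units; within the scatter) is not. Compound 4 `Nc1nc(-c2ncco2)nc2sc(Cc3ccccc3)cc12` differs from compound 3 by 1,3-oxazol-2-yl in place of oxolan-2-yl on an aromatic carbon. Both large steps to compound 3 exchanged an aromatic five-membered ring for oxolan-2-yl, so a partial return toward the lower numbers of compound 1 and compound 2 is expected in this assay, about a 3.7-fold lower number from compound 3 to compound 4 (0.57 log units; beyond the scatter). Compound 4 is estimated at 800 nM, within 250 nM to 2500 nM.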

Compound 4, inhibition constant: 310 nM
For compound 4 the middle estimate is 2.6-fold (0.41 log units) above the measured one, within the range that was stated.
By their numbers in this assay, from the lowest: compounds 1, 2 and 4 (each within the scatter of the next); then compound 3.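

In this assay the change back to an aromatic five-membered ring gives a 9.5-fold lower number from compound 3 to compound 4 (0.98 log units; beyond the scatter) and shows that 1,3-oxazol-2-yl, with no alkyl group on its ring, can replace oxolan-2-yl at this position. Against the substituted furans, a 1.1-fold higher number from compound 2 to compound 4 (0.04 log units; within the scatter) and a 1.4-fold higher number from compound 1 to compound 4 (0.14 log units; within the scatter) show no separation from 5-isopropylfuran-2-yl or 5-ethylfuran-2-yl, although ring and alkyl group change together in those steps.

Open, going by these compounds, is whether an ethyl group on the 1,3-oxazole or an unsubstituted furan-2-yl would separate these two contributions. No measurement at hand explains the difference between oxolan-2-yl and the aromatic rings.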